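Replacing methyl with methoxy on a weak norepinephrine transporter inhibitor

This account rests on a few compounds, and the source may have more. Where it says the series, first, only, none or still open, it means among the compounds named here.

Measured compounds:
- compound 1, `CN(C)C/C=C(/c1ccccc1)c1cccnc1`, 27000 nM
- compound 2, `CN(C)C/C=C(/c1ccc(I)cc1)c1cccnc1`, > 22000 nM
- compound 3, `Cc1ccc(/C(=C/CN(C)C)c2cccnc2)cc1`, > 29000 nM

All three share a core and differ only at one position on the phenyl ring. In a functional assay on brain for inhibition of Norepinephrine transporter (Rattus norvegicus) (a higher number here means a weaker inhibitor, a lower number a stronger inhibitor), compound 1 gives 27000 nM. Compound 2 gives > 22000 nM, which is a limit of the assay and not a number. Compound 3 gives > 29000 nM, which is also a limit of the assay and not a number. Compound 3 therefore stands at the weak end of what this assay can read, as the limit of > 29000 nM in this assay, at which 1 of the 3 values shown sits, shows; the step of an at least 1.0-fold higher number from compound 1 to compound 3 (0.03 log units; that floor lies within the scatter) has a floor that lies within the scatter, and the steps a step that the limit leaves unreadable from compound 1 to compound 2 and a step that the two limits leave unreadable from compound 2 to compound 3 cannot be sized.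

Compound 4, `COc1ccc(/C(=C/CN(C)C)c2cccnc2)cc1`, carries the change (methoxy in place of methyl on an aromatic carbon). Among the measured compounds shown here, no measured step involves a methoxy group, so nothing here speaks for a move of compound 4 beyond the scatter in either direction, and a further limit is the most likely outcome. Compound 4 is expected at 30000 nM, within 10000 nM to 100000 nM, which is the estimated step that the limit leaves unreadable from compound 3 to compound 4.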

Compound 4, half-maximal inhibitory concentration: > 28000 nM
Compound 4: only a limit was reported (the forecaster's own chance of this, stated with the estimate: 70%); the middle value lies beyond the limit too.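

Methoxy brings an oxygen and a hydrogen-bond acceptor that methyl lacks, yet compound 4 also stays at the weak end of what this assay can read: the limit of > 28000 nM in this assay, at which 1 of the 4 values shown sits. Among the compounds shown here, the one step with a readable floor is an at least 1.0-fold higher number from compound 1 to compound 4 (0.01 log units; that floor lies within the scatter). The steps to compound 4 from compound 2 and compound 3 cannot be read, as both ends of each are limits, so adding this acceptor on this carbon gives no sign of a stronger inhibitor.

As far as these compounds go, how far compound 2, compound 3 and compound 4 lie beyond their limits remains open, and so does any order among iodo, methyl and methoxy. Also open, from the compounds shown here alone, is whether an amine or a carboxylic acid at this position would give a value that can be read as a number.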